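The compounds below may be only part of what the source reports. "The series", "measured", "known", "first", "only" and "open" are said of these compounds alone.

Measured in a functional assay on SMMC-7721 cells (Homo sapiens) for antiproliferative activity, read by MTT assay, with a stated time of 72 h; on this read-out lower numbers stand for stronger inhibition and higher numbers for weaker inhibition:
- compound 1 `O=C(N/N=C/c1ccco1)c1cccc(S(=O)(=O)N2CCOCC2)c1`: > 100000 nM (a limit of the assay)
- compound 2 `O=C(N/N=C/c1ccccn1)c1cccc(S(=O)(=O)N2CCOCC2)c1`: > 100000 nM (a limit of the assay)
- compound 3 `COc1ccc(/C=N/NC(=O)c2cccc(S(=O)(=O)N3CCOCC3)c2)c(O)c1`: 3950 nM

Compound 3 is the only one of the three with an actual number, as the other two values are limits. The next compound to be tested is compound 4 `O=C(N/N=C/c1cc(Br)ccc1O)c1cccc(S(=O)(=O)N2CCOCC2)c1`. It differs from compound 3 in one group: 5-bromo-2-hydroxyphenyl in place of 2-hydroxy-4-methoxyphenyl on a carbon with a double bond to nitrogen. Within the data shown here, two measured steps bear on this, an at least 25-fold lower number from compound 1 to compound 3 (1.40 log units; beyond the scatter) and an at least 25-fold lower number from compound 2 to compound 3 (1.40 log units; beyond the scatter). Both are large, and both introduce the 2-hydroxy-4-methoxyphenyl group in place of a furan-2-yl or pyridin-2-yl group. The third step, a step that the two limits leave unreadable from compound 1 to compound 2, adds nothing. The new group in compound 4 is also a 2-hydroxy-substituted phenyl, so the large gain seen on reaching compound 3 is expected to survive, although this rests on a single compound with a number. The expected step is a 1.3-fold lower number from compound 3 to compound 4 (0.12 log units; within the scatter), which is no change beyond the scatter, with no firm direction. For compound 4 the estimated value is 3000 nM, with an expected range from 600 nM to 15000 nM.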

Compound 4, half-maximal inhibitory concentration: 9940 nM
Compound 4: middle estimate off by 3.3-fold (0.52 log units), on the low side; low and high end bracket the measured number.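

In this assay, replacing 2-hydroxy-4-methoxyphenyl with 5-bromo-2-hydroxyphenyl on a carbon with a double bond to nitrogen gives a 2.5-fold higher number from compound 3 to compound 4 (0.40 log units; beyond the scatter), so the read-out changes between two hydroxy-bearing phenyl groups, not only on leaving furan-2-yl or pyridin-2-yl. The gain over those two groups also no longer rests on compound 3 alone, with an at least 10-fold lower number from compound 2 to compound 4 (1.00 log units; beyond the scatter) and an at least 10-fold lower number from compound 1 to compound 4 (1.00 log units; beyond the scatter). Both of these steps are minimum sizes, set by a single limit: the limit of > 100000 nM in this assay, at which 2 of the 4 values shown sit.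

On these data alone, compound 3 and compound 4 differ in both the methoxy group and the bromine, so the share of each in the step stays open. Also open, as far as these compounds go, is how a plain phenyl group without the hydroxy group, or a phenyl group carrying an amine or a carboxylic acid, would read.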